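This account rests on a few compounds, and the source may have more. Where it says the series, first, only, none or still open, it means among the compounds named here.

In a functional assay on HT-29 cells (Homo sapiens) for antiproliferative activity, read by sulforhodamine B assay, with a stated time of 48 h (a higher number here means a weaker inhibitor, a lower number a stronger inhibitor), compound 1 `CCc1ccccc1OS(=O)(=O)c1ccc(N2CCN(C)C2=O)cc1` gives 4600 nM. Compound 2 `COc1ccccc1OS(=O)(=O)c1ccc(N2CCN(C)C2=O)cc1` differs from compound 1 by methoxy in place of ethyl on an aromatic carbon, and in this assay compound 2 gives 26000 nM, so that a 5.7-fold higher number from compound 1 to compound 2 (0.75 log units; beyond the scatter). Compound 3 `CCCN1CCN(c2ccc(S(=O)(=O)Oc3ccccc3CC)cc2)C1=O` has a different core, the difference being (ethyl in place of hydrogen on a saturated chain carbon bound to an amide-type nitrogen in a ring). In this assay compound 3 reaches only a limit of the measurement, > 100000 nM, which is the limit of > 100000 nM in this assay, at which 1 of the 3 values shown sits. Accordingly an at least 21-fold higher number from compound 1 to compound 3 (1.33 log units; beyond the scatter). Compound 4 `CCCN1CCN(c2ccc(S(=O)(=O)Oc3ccccc3OC)cc2)C1=O` has not been measured; it stands to compound 3 as compound 2 stands to compound 1, the change being (methoxy in place of ethyl on an aromatic carbon), the same change at the same kind of place as between compound 1 and compound 2. Compound 3 already sits at the limit, so compound 4 is expected to remain there too, an expected step that the limit leaves unreadable from compound 3 to compound 4. That expectation rests on the measured step of a 5.7-fold higher number from compound 1 to compound 2 (0.75 log units; beyond the scatter) for the same change. The estimate for compound 4 is 400000 nM, between 100000 nM and 2000000 nM.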

Compound 4, half-maximal inhibitory concentration: > 100000 nM
Compound 4: only a limit was reported (the forecaster's own chance of this, stated with the estimate: 90%); the middle value lies beyond the limit too.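

In this assay compound 4 gives > 100000 nM, which is a limit of the assay and not a number. From the compounds shown here alone, the step for methoxy in place of ethyl cannot be read on this core, so it remains unknown whether the change seen on the core of compound 1 carries over. The other change, ethyl in place of hydrogen on the saturated chain carbon, can be followed with the methoxy group in place, giving an at least 3.8-fold higher number from compound 2 to compound 4 (0.58 log units; beyond the scatter), and it raises the number on both cores, though the sizes cannot be compared: the same change on two cores in this assay, an at least 21-fold higher number (1.33 log units; beyond the scatter) from compound 1 to compound 3 and an at least 3.8-fold higher number (0.58 log units; beyond the scatter) from compound 2 to compound 4; the limit leaves it open whether they differ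

The compounds shown leave open how a longer chain, or a chain ending in an amine, would behave on that ring nitrogen. They also leave open whether a carboxylic acid on the aromatic ring in place of methoxy or ethyl would bring the propyl-bearing core back within measurable range.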